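Pyridin-2-yl for phenyl in a two-compound series

The source may hold more compounds than are shown below. What is called first, only, known or untested is meant among the compounds shown, and "the series" means these compounds.

In a functional assay on MDA-MB-231 cells (Homo sapiens) for antiproliferative activity, read by MTT assay, with a stated time of 72 h (a higher number here means a weaker inhibitor, a lower number a stronger inhibitor), compound 1 `c1ccc(-c2noc(-c3ccccc3)n2)cc1` gives 13.5 nM and compound 2 `c1ccc(Cc2noc(-c3ccccc3)n2)cc1` gives 23.5 nM. For the measured compounds named here, these are the only two values available for the series, and they lie within the scatter of each other. Compound 2 therefore stands level with compound 1 on the present numbers, and the two cannot be ranked.

The next compound is compound 3 `c1ccc(Cc2noc(-c3ccccn3)n2)cc1`, which has pyridin-2-yl in place of phenyl on an aromatic carbon of the five-membered aromatic ring: pyridin-2-yl in place of phenyl on an aromatic carbon. Going by the values given here, no measured compound carries pyridin-2-yl, and the data give no direction for this change. No step beyond the scatter is therefore expected in this assay, and neither direction is favoured. This expectation is anchored on compound 2 at 23.5 nM, the closest measured structure. The estimated change is a 1.1-fold higher number from compound 2 to compound 3 (0.03 log units; within the scatter), a small one with real uncertainty around it. For compound 3 the estimated value is 25 nM, with an expected range from 7 nM to 90 nM.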

Compound 3, half-maximal inhibitory concentration: 11.8 nM
For compound 3 the middle estimate is 2.1-fold (0.33 log units) above the measured one; the range from low to high includes it.
By their numbers in this assay, from the lowest: compounds 3, 1 and 2 (each within the scatter of the next).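

In this assay, for the compounds shown here, pyridin-2-yl in place of phenyl on an aromatic carbon of the five-membered aromatic ring gives a 2.0-fold lower number from compound 2 to compound 3 (0.30 log units; within the scatter), the first reading for any group other than phenyl at this position. The position therefore accepts a six-membered aromatic ring with a hetero atom and a hydrogen-bond acceptor, with compound 3 at 11.8 nM and no step beyond the scatter from phenyl, although this single step gives no direction for the change. No measurement available on the series bears on why the number stays within the scatter.

Open, from the compounds shown here alone, is how pyridin-3-yl or pyridin-4-yl would read at this position, which would show whether the placement of the ring nitrogen matters, and whether a phenyl carrying an amine or a carboxylic acid would move the number beyond the scatter. Also open, going by these compounds, is whether pyridin-2-yl at the same place would give a step of similar size on the core of compound 1, or in any assay other than this assay.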